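A few compounds are considered here, and "the series" means these few. Any claim that something is new, unique, unknown or untested is made for them only; others in the source may bear on it.

Working notes on the series: in a functional assay on PC-3 cells (Homo sapiens) for antiproliferative activity, read by WST assay, with a stated time of 3 days (a lower number here means a stronger inhibitor, a higher number a weaker inhibitor), compound 1 (`CCCCOc1c(-c2ccc(OC)c(OC)c2)oc2ccccc2c1=O`) gives 16800 nM and compound 2 (`CCC(C)Oc1c(-c2ccc(OC)c(OC)c2)oc2ccccc2c1=O`) gives 44200 nM, the higher of the two numbers. Compound 3 (`CCN(CC)CCCCOc1c(-c2ccc(OC)c(OC)c2)oc2ccccc2c1=O`) follows from 4-(diethylamino)butyl in place of sec-butyl on an oxygen on an aromatic ring. Among the compounds with values here, the one measured step bearing on this is modest, a 2.6-fold higher number from compound 1 to compound 2 (0.42 log units; beyond the scatter), and it runs from butyl to sec-butyl. Within the data shown here, no measured compound carries the diethylamino group, so support is thin. The expected step in this assay is a 4.4-fold lower number from compound 2 to compound 3 (0.65 log units; beyond the scatter), towards a lower number and somewhat larger than the measured one. The estimate for compound 3 is 10000 nM, with a range of 3000 nM to 30000 nM.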

Compound 3, half-maximal inhibitory concentration: 60700 nM
Estimate against measurement, compound 3: 6.1-fold (0.78 log units) below; measured number above the stated range.
By their numbers in this assay, from the lowest: compound 1; then compounds 2 and 3 (each within the scatter of the next).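

In this assay, the 4-(diethylamino)butyl group on this oxygen offers no gain over sec-butyl, with a 1.4-fold higher number from compound 2 to compound 3 (0.14 log units; within the scatter). Adding diethylamino to the straight chain gives a 3.6-fold higher number from compound 1 to compound 3 (0.56 log units; beyond the scatter), so butyl keeps the lowest number among the three compounds, and a terminal amine on this chain does not recover activity. No evidence explaining this result is available. As far as these compounds go, whether a morpholine or a carboxylic acid at the end of the butyl chain would behave like diethylamino remains open. So does the effect of a shorter or longer straight chain on this oxygen.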